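A few compounds are considered here, and "the series" means these few. Any claim that something is new, unique, unknown or untested is made for them only; others in the source may bear on it.

Measured compounds:
Compound 1, `COc1cc(C)cc(-c2c(-c3ccnc(-c4ccc(C(C)=O)cc4)c3)cnn2CC#N)c1`. In a functional assay on MCF7 cells (Homo sapiens) for inhibition, read by sulforhodamine B assay, with a stated time of 48 h (a lower number here means a stronger inhibitor of growth, a higher number a weaker inhibitor of growth), compound 1 gives > 100000 nM, which is a limit of the assay and not a number.
Compound 2, `Cc1cc(O)cc(-c2nn(CC#N)cc2-c2ccnc(-c3ccc(Oc4ccccc4)cc3)c2)c1`. In this assay compound 2 gives 5480 nM.

Compound 2 thus carries the only number shown in this assay; the other value is the limit of > 100000 nM in this assay, at which 1 of the 2 values shown sits. Among the measured compounds shown here, no pair of measured compounds that differ in one place is available, so nothing tells how far a single change moves the read-out.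

Compound 3, `Cc1cc(O)cc(-c2nn(CC#N)cc2-c2ccnc(-c3ccc(N(C)C)cc3)c2)c1`, differs from compound 2 in one place: dimethylamino in place of phenoxy on an aromatic carbon. In words, dimethylamino in place of phenoxy on an aromatic carbon. For the measured compounds named here, no measured pair shows what this exchange does here, so the expectation is wide. The step of a 1.5-fold higher number from compound 2 to compound 3 (0.16 log units; within the scatter) is expected to be modest, in either direction, and may fall within the scatter. Compound 3 is estimated at 8000 nM in this assay, with a range from 2000 nM to 40000 nM.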

Compound 3, concentration for total growth inhibition: 13900 nM
Beside the measured number, compound 3's estimate is 1.7-fold (0.24 log units) below it, within the range that was stated.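

In this assay, among the compounds shown here, the series now has its only measured one-place exchange: dimethylamino in place of phenoxy, on an aromatic carbon para to a large group, gives a 2.5-fold higher number from compound 2 to compound 3 (0.40 log units; beyond the scatter). The step lies beyond the scatter yet is modest, so this position accepts the loss of the six-membered aromatic ring of carbon only while compound 3 still gives a number and not a limit. Nothing measured here accounts for the size of this step.

With a single exchange at this position, the departure of the ring and the change from oxygen to nitrogen on the aromatic carbon cannot be told apart. The compounds shown leave open where a primary amine or a carboxylic acid at this position would fall relative to compound 2 and compound 3.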